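Methylating the Amide Nitrogen of Compound 2

The source may hold more compounds than are shown below. What is called first, only, known or untested is meant among the compounds shown, and "the series" means these compounds.

Compound 2 `CC(C)(C(N)=O)C(c1ccc(Nc2ccc3ccccc3c2)cc1)n1ccnc1` and compound 1 `CC(C)(C(=O)O)C(c1ccc(Nc2ccc3ccccc3c2)cc1)n1ccnc1` share one core and differ only in the group on the carbonyl carbon. In an assay on isolated protein for inhibition of cytochrome P450 26A1 (Homo sapiens), read by scintillation counting (a higher number here means a weaker inhibitor, a lower number a stronger inhibitor), compound 1 gives 300 nM and compound 2 gives 50 nM. Among the measured compounds shown here, the one measured change, a 6.0-fold lower number from compound 1 to compound 2 (0.78 log units; beyond the scatter), was amino in place of hydroxy on a carbonyl carbon, a modest gain. On these two numbers compound 2 stands lowest, the stronger inhibitor of the pair. Compound 3 `CNC(=O)C(C)(C)C(c1ccc(Nc2ccc3ccccc3c2)cc1)n1ccnc1` carries methyl in place of hydrogen on an amide-type nitrogen: a hydrogen leaves and a methyl enters, turning carbamoyl into methylcarbamoyl. For the measured compounds named here, no measured step touches this amide-type nitrogen; the only known step concerns the carbonyl carbon itself, so it gives no direct guide. With nothing pointing either way, the expected step is a 1.2-fold higher number from compound 2 to compound 3 (0.08 log units; within the scatter), not beyond the usual scatter. Compound 3 is therefore estimated at 60 nM, with a range from 20 nM to 180 nM.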

Compound 3, half-maximal inhibitory concentration: 12 nM
Beside the measured number, compound 3's estimate is 5.0-fold (0.70 log units) above it, and the stated range ends above it.
By their numbers in this assay, from the lowest: compound 3; then compound 2; then compound 1.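

At this nitrogen, a single methyl in place of the amide hydrogen is not a neutral swap: in this assay it gives a clear gain (a 4.2-fold lower number from compound 2 to compound 3 (0.62 log units; beyond the scatter)). Compound 1 had shown only that the group on the carbonyl carbon matters; the comparison with the methylamino group now gives a large step (a 25-fold lower number from compound 1 to compound 3 (1.40 log units; beyond the scatter)), so the amide nitrogen itself is also a place where small changes count. No measurement at hand explains the gain.

On these data alone, whether a longer chain on this nitrogen, such as ethyl or propyl, would take the number lower still or reverse the gain remains open. So does the effect of a dimethylcarbamoyl group, which would carry methyl in place of the remaining amide hydrogen as well.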